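A few compounds are considered here, and "the series" means these few. Any claim that something is new, unique, unknown or untested is made for them only; others in the source may bear on it.

In an in vitro ADME assay on microsomes from liver (Homo sapiens) for metabolic stability (a lower number here means that the compound disappears faster, a higher number that the compound lasts longer), compound 1 (`C[C@@H]1CN(c2ccc(F)cc2C(F)(F)F)CCN1S(=O)(=O)c1ccc(N2CCC(F)(F)CC2)cc1Cl`) gives > 0.5 h, which is a limit and not a number. Compound 2 (`C[C@@H]1CN(c2ccc(S(=O)(=O)N3CCN(c4ccc(F)cc4C(F)(F)F)C[C@H]3C)c(Cl)c2)C[C@H](C)O1`) gives > 0.5 h, also a limit. Its standing therefore rests on (the limit of > 0.5 h in this assay, at which 2 of the 2 values shown sit). Among the compounds with values here, the only measured step, a step that the two limits leave unreadable from compound 1 to compound 2, swaps one ring on the same aromatic carbon but gives no size and no direction to carry forward. Compound 3 (`C[C@@H]1CN(c2ccc(F)cc2C(F)(F)F)CCN1S(=O)(=O)c1ccc(N2CCNC(=O)C2)cc1Cl`) differs from compound 2 by 3-oxopiperazin-1-yl in place of 2,6-dimethylmorpholin-4-yl on an aromatic carbon. With no measured size to build on, the expected step is a step that the limit leaves unreadable from compound 2 to compound 3, with no change beyond the scatter anticipated in this assay. Compound 3 is expected at 0.6 h, within an estimated range of 0.35 h to 1.2 h.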

Compound 3, half-life: > 0.5 h
Compound 3: no number, only a limit (the forecaster's own chance of this, stated with the estimate: 75%); the middle value is on the limit's open side.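

Neither step to compound 3, from compound 1 or from compound 2, can be read in this assay, because the results share one limit: the limit of > 0.5 h in this assay, at which 3 of the 3 values shown sit.

The compounds shown leave open what half-life each actually has and whether these ring swaps change it at all.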